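A few compounds are considered here, and "the series" means these few. Any claim that something is new, unique, unknown or untested is made for them only; others in the source may bear on it.

Compound 1 `CC1=NC(C)=C([N+](=O)[O-])C(c2ccncc2)/C1=C(\O)OC(C)(C)C` is the reference in this set. In a functional assay (cardiac atrium) for agonist activity, with Cavia porcellus as the target (on this read-out lower numbers stand for an effect already at smaller amounts and higher numbers for an effect only at larger amounts of compound), compound 1 gives 2820 nM. Compound 2 `COCCO/C(O)=C1\C(C)=NC(C)=C([N+](=O)[O-])C1c1ccncc1` differs from it by 2-methoxyethyl in place of tert-butyl on an oxygen on an unsaturated carbon, and in this assay compound 2 gives 37700 nM, a step of a 13-fold higher number from compound 1 to compound 2 (1.13 log units; beyond the scatter). Compound 3 `CC1=NC(C)=C([N+](=O)[O-])C(c2cccnc2)/C1=C(\O)OC(C)(C)C` carries a different core, described by pyridin-3-yl in place of pyridin-4-yl on a saturated ring carbon; in this assay compound 3 gives 14600 nM, a step of a 5.2-fold higher number from compound 1 to compound 3 (0.71 log units; beyond the scatter). Compound 4 `COCCO/C(O)=C1\C(C)=NC(C)=C([N+](=O)[O-])C1c1cccnc1` has not yet been measured. Among the compounds with values here, it is related to compound 3 by 2-methoxyethyl in place of tert-butyl on an oxygen on an unsaturated carbon, the same change as the one from compound 1 to compound 2, made on the core of compound 3. If that change behaves as it did before, the step from compound 3 to compound 4 is expected to be about a 12-fold higher number from compound 3 to compound 4 (1.09 log units; beyond the scatter), because the earlier one was a 13-fold higher number from compound 1 to compound 2 (1.13 log units; beyond the scatter). On that basis compound 4 is estimated at 180000 nM, within 50000 nM to 600000 nM.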

Compound 4, half-maximal effective concentration: 49400 nM
Estimate against measurement, compound 4: 3.6-fold (0.56 log units) above; measured number outside the range, below it.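

In this assay the change from tert-butyl to 2-methoxyethyl on the core of compound 3 gives a 3.4-fold higher number from compound 3 to compound 4 (0.53 log units; beyond the scatter), so the direction carries over but the size does not: the same change on two cores in this assay, a 13-fold higher number (1.13 log units; beyond the scatter) from compound 1 to compound 2 and a 3.4-fold higher number (0.53 log units; beyond the scatter) from compound 3 to compound 4, 4.0-fold (0.60 log units) apart, beyond the scatter of two such steps. The change from pyridin-4-yl to pyridin-3-yl likewise shrinks on the 2-methoxyethyl side to a 1.3-fold higher number from compound 2 to compound 4 (0.12 log units; within the scatter), a step within the scatter: the same change on two cores in this assay, a 5.2-fold higher number (0.71 log units; beyond the scatter) from compound 1 to compound 3 and a 1.3-fold higher number (0.12 log units; within the scatter) from compound 2 to compound 4, 4.0-fold (0.60 log units) apart, beyond the scatter of two such steps. These four compounds show that the two changes do not simply add up here, but they do not show why, nor how either change would behave on any other core.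

The compounds shown leave open whether a longer chain, an amine or a carboxylic acid in place of tert-butyl would follow the same course. On these data alone, how a phenyl ring in place of the pyridinyl groups would behave also remains open.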